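This account rests on a few compounds, and the source may have more. Where it says the series, first, only, none or still open, it means among the compounds named here.

Measured so far in an ADME assay on Raji cells (Homo sapiens) for cytotoxicity, with a stated time of 72 h; a higher number here means that more compound is needed for the effect, a lower number that less compound is needed:

Compound 1, `COc1ccc(NC(=O)Nc2cc(C)nc3ccccc23)cc1F`, gives > 25000 nM, which is a limit of the assay rather than a number.
Compound 2, `Cc1cc(NC(=O)Nc2ncccc2C)c2ccccc2n1`, gives > 25000 nM, again a limit of the assay.
Compound 3, `Cc1cc(NC(=O)Nc2ccccc2C(F)(F)F)c2ccccc2n1`, gives > 25000 nM, once more a limit of the assay.

All three compounds share a core carrying a urea-type linker, and differ only in the aromatic group on the far amide-type nitrogen. In this assay none of them reaches a measurable effect: every value sits at the limit of > 25000 nM in this assay, at which 3 of the 3 values shown sit. Compound 2 therefore stands at that limit, with no number of its own, and the two other values shown are limits as well, so no ordering among the three can be drawn.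

Compound 4, `Cc1cc(NC(=O)Nc2cccc(Cl)c2)c2ccccc2n1`, has not yet been measured. It differs from compound 2 by 3-chlorophenyl in place of 3-methylpyridin-2-yl on an amide-type nitrogen. Among the measured compounds shown here, no step between two measured compounds is available to gauge the effect of such a change. Since the three values seen so far all rest at the same limit, the step that the limit leaves unreadable from compound 2 to compound 4 is expected to be none beyond the scatter, and compound 4 is estimated at 30000 nM, within a range from 12000 nM to 100000 nM.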

Compound 4, half-maximal effective concentration: 18000 nM
Estimate against measurement, compound 4: 1.7-fold (0.22 log units) above; low and high end bracket the measured number.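

In this assay compound 4 gives 18000 nM, the first actual number among the compounds shown. Compound 1, compound 2 and compound 3 each rest at a limit of the assay. This shows that a compound with 3-chlorophenyl at this amide-type nitrogen, whose other neighbour is the carbonyl carbon, can be read on the scale of the assay. Replacing 3-methylpyridin-2-yl with 3-chlorophenyl gives an at least 1.3-fold lower number from compound 2 to compound 4 (0.14 log units; that floor lies within the scatter) and so leaves a real change possible but unproven, and its true size stays unknown because compound 2 has only a limit: the limit of > 25000 nM in this assay, at which 3 of the 4 values shown sit.

The compounds shown leave open whether the chlorine or the carbon-only ring goes with the readable value, a question that a plain phenyl group at the same nitrogen could help to separate. They also leave open how far the number would move with a different kind of group on that ring, such as an amine or a carboxylic acid.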